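The source may report more compounds than this note shows. Statements on the series, on what has been measured and on what is new or still open speak of the compounds shown alone.

Compound 1 `O=C(CN1CCC(Cc2ccccc2)CC1)Nc1ccc(C(=O)/C=C/c2cn(Cc3ccc(Br)cc3)nn2)cc1` and compound 2 `COc1ccccc1N1CCN(CC(=O)Nc2ccc(C(=O)/C=C/c3cn(Cc4ccc(Br)cc4)nn3)cc2)CC1` share a core and differ only in the amine attached to the amide. In a functional assay on MCF7 cells (Homo sapiens) for inhibition, read by MTT assay (a lower number here means a stronger inhibitor, a higher number a weaker inhibitor), compound 1 gives 54500 nM, and compound 2 gives 36800 nM. These two numbers lie within the usual scatter of each other, and neither compound can be called the stronger. Compound 3 `CCCCCCCCn1cc(/C=C/C(=O)c2ccc(NC(=O)CN3CCC(Cc4ccccc4)CC3)cc2)nn1` keeps the core of compound 1 and changes a single group: heptyl in place of 4-bromophenyl on a saturated chain carbon bound to an aromatic nitrogen. Within the data shown here, no measured pair shows what this change does. The step of a 1.1-fold higher number from compound 1 to compound 3 (0.04 log units; within the scatter) is expected to be small, with no clear direction beyond the scatter. Compound 3 is therefore estimated at 60000 nM, with a range from 20000 nM to 200000 nM.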

Compound 3, half-maximal inhibitory concentration: 52600 nM
The estimate for compound 3 lay 1.1-fold (0.06 log units) above the measured number, within the range that was stated.
By their numbers in this assay, from the lowest: compounds 2, 3 and 1 (each within the scatter of the next).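

In this assay, heptyl in place of 4-bromophenyl on a saturated chain carbon bound to an aromatic nitrogen gives a 1.0-fold lower number from compound 1 to compound 3 (0.02 log units; within the scatter), so the two numbers cannot be told apart. This pair shows that a chain without a ring and a bromine-bearing aromatic ring read alike here, at the same count of heavy atoms. Nothing measured here bears on why they read alike. As far as these compounds go, whether an amine or a carboxylic acid at this place would shift the number beyond the scatter stays open. So does whether a much shorter chain, such as ethyl, would.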